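The source may report more compounds than this note shows. Statements on the series, on what has been measured and on what is new or still open speak of the compounds shown alone.

Compound 2 `Nc1sc(-c2ccc(Cl)cc2)c(-c2ccc(Cl)cc2)c1C(=O)N1CCC(=O)CC1=O` gives 4090 nM in a functional assay on A549 cells (Homo sapiens) for inhibition, read by sulforhodamine B assay, with a stated time of 72 h (on this read-out lower numbers stand for stronger inhibition and higher numbers for weaker inhibition), the highest of the two numbers seen so far. Within the data shown here, its only neighbour, compound 1 `Nc1sc(-c2ccc(Cl)cc2)c(-c2ccc(Cl)cc2)c1C(=O)N1CCNCC1`, gives 1020 nM; the step of a 4.0-fold higher number from compound 1 to compound 2 (0.60 log units; beyond the scatter) is the single measured change on the carbonyl carbon. Compound 3 `COC(=O)c1c(N)sc(-c2ccc(Cl)cc2)c1-c1ccc(Cl)cc1` carries the next change there, (methoxy in place of 2,4-dioxopiperidin-1-yl on a carbonyl carbon). Among the measured compounds shown here, no measured pair mirrors a methoxycarbonyl in place of an amide, so the step from compound 1 to compound 2 only bounds the likely size. For compound 3 a step of a 1.1-fold higher number from compound 2 to compound 3 (0.04 log units; within the scatter) is expected, within the scatter, giving an estimate of 4500 nM in this assay, between 1500 nM and 14000 nM.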

Compound 3, half-maximal inhibitory concentration: 5040 nM
The estimate for compound 3 lay 1.1-fold (0.05 log units) below the measured number; measured number inside the range.
By their numbers in this assay, from the lowest: compound 1; then compounds 2 and 3 (each within the scatter of the next).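

In this assay the much smaller methoxy on the carbonyl carbon gives a 1.2-fold higher number from compound 2 to compound 3 (0.09 log units; within the scatter), so the 2,4-dioxopiperidin-1-yl ring and methoxy cannot be told apart here. Piperazin-1-yl alone stands apart, with a 4.9-fold higher number from compound 1 to compound 3 (0.69 log units; beyond the scatter), and compound 1 keeps the lowest number of the three. No evidence at hand accounts for these numbers.

From the compounds shown here alone, whether the lower number of compound 1 belongs to the piperazin-1-yl ring as a whole or to any amine on this carbonyl carbon stays open. A morpholine amide, an open-chain aminoethyl amide or a carboxylic acid there would separate these readings.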